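Chloro for methyl on an anilide: cytotoxicity unreadable

The compounds below may be only part of what the source reports. "The series", "measured", "known", "first", "only" and "open" are said of these compounds alone.

Compound 1, `O=C(CSC(=S)N[C@H]1CCOC1=O)Nc1ccc(Cl)cc1`: in a functional assay on EC9706 cells (Homo sapiens) for cytotoxicity, read by MTT assay, with a stated time of 72 h (on this read-out lower numbers stand for stronger inhibition and higher numbers for weaker inhibition), compound 1 gives > 128000 nM, which is a limit of the assay and not a number.
Compound 2, `Cc1cccc(NC(=O)CSC(=S)N[C@H]2CCOC2=O)c1`: in this assay compound 2 gives > 128000 nM, again a limit rather than a number.

Compound 2 therefore stands only at a limit, as does the other measured compound, both sitting at the limit of > 128000 nM in this assay, at which 2 of the 2 values shown sit. Going by the values given here, the single measured step, a step that the two limits leave unreadable from compound 1 to compound 2, is left unreadable by those two limits. Compound 3, `O=C(CSC(=S)N[C@H]1CCOC1=O)Nc1cccc(Cl)c1`, differs from compound 2 by chloro in place of methyl on an aromatic carbon. With no readable step to draw on, no direction can be expected beyond the scatter. Compound 3 is estimated at 128000 nM, between 30000 nM and 250000 nM, most probably reported once more as a limit. The expected step of a number no higher from compound 2 to compound 3 (the limit leaves the size open) is thus none beyond the scatter.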

Compound 3, half-maximal inhibitory concentration: 107000 nM
For compound 3 the middle estimate is 1.2-fold (0.08 log units) above the measured one, and the stated range covers the measured number.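

Going by these compounds alone, replacing methyl with chloro at this place yields the first actual number in this assay, so the change can now be bounded from one side: an at least 1.1-fold lower number from compound 2 to compound 3 (0.07 log units; that floor lies within the scatter). Exchanging 4-chlorophenyl for 3-chlorophenyl gives an at least 1.1-fold lower number from compound 1 to compound 3 (0.07 log units; that floor lies within the scatter). Neither floor clears the scatter, and the true sizes of both steps cannot be read, as the other two compounds remain at a limit: the limit of > 128000 nM in this assay, at which 2 of the 3 values shown sit.

The step between those two limits cannot be read either. As far as these compounds go, whether an amine or a carboxylic acid on this ring would bring the number down remains open.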